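The compounds below may be only part of what the source reports. "The series", "measured", "known", "first", "only" and "open" are said of these compounds alone.

Compound 1, `NC(=O)C1CCN(c2nc(-c3ccccn3)nc3c2CN(Cc2ccccc2)CC3)CC1`, is the starting point of this short series. In an assay on FRT cells with Cystic fibrosis transmembrane conductance regulator variant F508del (Homo sapiens) as the target, read by fluorescence, with a stated time of 25 min (a higher number here means a larger maximal response, a lower number a smaller maximal response), compound 1 gives 56.6%. Compound 2, `CN(C)CCN1CCN(c2nc(-c3ccccn3)nc3c2CN(Cc2ccccc2)CC3)CC1`, differs from it in one place, and in this assay compound 2 gives 41.3%; the step of a number 15.3 percentage points lower from compound 1 to compound 2 (beyond the scatter) is beyond the scatter but modest in size.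

Compound 3, `COc1ccc(CN2CCc3nc(-c4ccccn4)nc(N4CCN(CCN(C)C)CC4)c3C2)cc1`, carries the same side group as compound 2 on a core that differs elsewhere. For the measured compounds named here, for compound 3 this assay reports "not active" (no number reported) and no number at all, only that the compound was not active, so there is no value to place it against compound 1 or compound 2.

Compound 4, `COc1ccc(CN2CCc3nc(-c4ccccn4)nc(N4CCC(C(N)=O)CC4)c3C2)cc1`, has not yet been measured. Its difference from compound 3 is 4-carbamoylpiperidin-1-yl in place of 4-(2-(dimethylamino)ethyl)piperazin-1-yl on an aromatic carbon. This is the same exchange that separates compound 1 from compound 2, run in the opposite direction, and on that pair the step was a number 15.3 percentage points lower from compound 1 to compound 2 (beyond the scatter). As far as these compounds go, a gain of a similar size is therefore the expectation for compound 4 in this assay, starting from an inactive compound 3 whose level is unknown. Compound 4 is estimated to give 35%, with a range from 10% to 60%.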

Compound 4, largest response reached (Emax), in percent of the reference or control that the assay uses: 86.6%
Compound 4: middle estimate off by 51.6 percentage points, on the low side, outside the stated range (above it).
By their numbers in this assay, from the lowest: compound 2; then compound 1; then compound 4.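

The group on this aromatic carbon decides more than the opening pair suggested: on the methoxy-bearing core, 4-carbamoylpiperidin-1-yl in place of 4-(2-(dimethylamino)ethyl)piperazin-1-yl separates compound 3, reported as not active, from compound 4, which gives 86.6% in this assay, although the size of that change cannot be read without a number for compound 3. The result also shows that the methoxy group does not act the same way with both side groups: alongside 4-carbamoylpiperidin-1-yl it brings a number 30 percentage points higher from compound 1 to compound 4 (beyond the scatter), whereas alongside 4-(2-(dimethylamino)ethyl)piperazin-1-yl, compound 2 gives 41.3% and its methoxy partner, compound 3, is reported as not active. No measurement is available that explains this reversal.

As far as these compounds go, it remains open whether the carbamoyl group itself matters, since these compounds do not show how a carboxylic acid or a nitrile would behave in its place on the piperidine ring. From the compounds shown here alone, it is equally open whether the gain belongs to methoxy in particular, or whether an ethoxy group or a fluorine atom in the same place would pair with 4-carbamoylpiperidin-1-yl in a similar way.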